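From Bromophenyl to Thiophenyl: an Estimate for Compound 4

The source may hold more compounds than are shown below. What is called first, only, known or untested is meant among the compounds shown, and "the series" means these compounds.

compound 1 `COc1cc(C(=O)c2sc(-c3ccc(Br)cc3)cc2N)cc(OC)c1OC`: 100 nM
compound 2 `COc1cc(C(=O)c2sc(-c3ccc(I)cc3)cc2N)cc(OC)c1OC`: 400 nM
compound 3 `COc1cc(C(=O)c2sc(-c3ccc(C)cc3)cc2N)cc(OC)c1OC`: 18 nM

In a functional assay on L1210 cells (Mus musculus) for antiproliferative activity (on this read-out lower numbers stand for stronger inhibition and higher numbers for weaker inhibition), compound 1 gives 100 nM, the second highest of the three numbers; compound 2 gives 400 nM and compound 3 gives 18 nM. Compound 4 `COc1cc(C(=O)c2sc(-c3cccs3)cc2N)cc(OC)c1OC` differs from compound 1 by thiophen-2-yl in place of 4-bromophenyl on an aromatic carbon. Two measured steps change the same aromatic carbon: a 4.0-fold higher number from compound 1 to compound 2 (0.60 log units; beyond the scatter) and a 5.6-fold lower number from compound 1 to compound 3 (0.74 log units; beyond the scatter), both beyond the scatter and pointing in opposite directions. Within the data shown here, neither brings in a five-membered ring, so no measured step matches this change closely, and the direction remains open. A modest step is the most that can be expected. Compound 4 is therefore estimated at 60 nM, with a range from 15 nM to 250 nM, which would be an expected 1.7-fold lower number from compound 1 to compound 4 (0.22 log units; within the scatter).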

Compound 4, half-maximal inhibitory concentration: 9.8 nM
Estimate against measurement, compound 4: 6.1-fold (0.79 log units) above; measured number outside the range, below it.
By their numbers in this assay, from the lowest: compounds 4 and 3 (each within the scatter of the next); then compound 1; then compound 2.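

In this assay the thiophen-2-yl ring on this aromatic carbon outdoes both halogen-bearing rings, with a 10-fold lower number from compound 1 to compound 4 (1.01 log units; beyond the scatter) and a 41-fold lower number from compound 2 to compound 4 (1.61 log units; beyond the scatter) as two large steps. Against the methyl-bearing ring the change gives a 1.8-fold lower number from compound 3 to compound 4 (0.26 log units; within the scatter) and so separates neither compound, which shows that a five-membered aromatic ring with one sulfur serves here as well as 4-methylphenyl. No evidence at hand bears on why the smaller ring does so well. Still open, from the compounds shown here alone, is whether the ring sulfur matters, which furan-2-yl or thiophen-3-yl could test. Also open, going by these compounds, is whether a methyl or a bromine on the thiophen-2-yl ring would keep this level.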